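The source may hold more compounds than are shown below. What is called first, only, known or untested is meant among the compounds shown, and "the series" means these compounds.

Measured so far in an ADME assay on the whole organism with Oryza sativa as the target, tested at 0.1 uM; a higher number here means a weaker effect of the compound at the concentration tested, a lower number a stronger effect:
compound 1, `CCc1cccc(NC(=O)N[C@H](C)c2ccccc2)c1`: 97%
compound 2, `C[C@@H](NC(=O)Nc1cccc(C(F)(F)F)c1)c1ccccc1`: 82%
compound 3, `C[C@@H](NC(=O)Nc1cccc(F)c1)c1ccccc1`: 99%

Compound 3 holds the highest of the three numbers. Its nearest neighbour is compound 1, whose value lies within the scatter of it; its furthest is compound 2, and the gap a number 17 percentage points higher from compound 2 to compound 3 (beyond the scatter) is beyond the scatter.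

Compound 4 is `C[C@@H](NC(=O)Nc1cccc(Br)c1)c1ccccc1`. It differs from compound 3 in one place:
bromo in place of fluoro on an aromatic carbon

Two measured steps reach compound 3 through a change at the same aromatic carbon. a number 2 percentage points higher from compound 1 to compound 3 (within the scatter) stays within the scatter, whereas a number 17 percentage points higher from compound 2 to compound 3 (beyond the scatter) is beyond it. Of the three groups tried there, only trifluoromethyl pulls the number down; ethyl and fluoro give values within the scatter of each other. Bromo in place of fluoro is expected to sit with the ethyl and fluoro cases rather than with trifluoromethyl, so the step expected for compound 4 is a number 5 percentage points lower from compound 3 to compound 4 (within the scatter), none beyond the scatter. The estimate for compound 4 in this assay is 94%, with a range of 80% to 100%.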

Compound 4, a percentage reported as activity, at one concentration (the size of the read-out at that concentration, not a potency): 100%
Estimate against measurement, compound 4: 6 percentage points below; low and high end bracket the measured number.
By their numbers in this assay, from the lowest: compound 2; then compounds 1, 3 and 4 (each within the scatter of the next).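

In this assay bromo joins the groups that cannot be told apart at this aromatic carbon: bromo in place of fluoro gives a number 1 percentage points higher from compound 3 to compound 4 (within the scatter) and bromo in place of ethyl gives a number 3 percentage points higher from compound 1 to compound 4 (within the scatter) in the same comparison. Bromo in place of trifluoromethyl gives a number 18 percentage points higher from compound 2 to compound 4 (beyond the scatter) and thus a second halogen-bearing contrast with compound 2, which among the four compounds is the only one set apart. Trifluoromethyl therefore remains the only group tried at this position that goes with a lower number, and nothing measured here bears on the reason.

The compounds shown leave open whether a lower number stays with trifluoromethyl alone or also appears with a nitrile, a methoxy group or a carboxylic acid on the same aromatic carbon. A read-out at one concentration also leaves open how compound 2 compares with the others as a potency.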